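Bromo for Methoxy: Cytotoxicity Outlook for Compound 4

This account rests on a few compounds, and the source may have more. Where it says the series, first, only, none or still open, it means among the compounds named here.

The measured compounds:
- compound 1 `Cc1cc(CCC#N)cc(C)c1Oc1cc(Nc2ccc(C#N)cc2)c(N)cc1Cl`: 10400 nM
- compound 2 `COC(=O)c1cc(N)c(Nc2ccc(C#N)cc2)cc1Oc1c(OC)cc(CCC#N)cc1OC`: 128000 nM
- compound 3 `CNC(=O)c1cc(N)c(Nc2ccc(C#N)cc2)cc1Oc1c(OC)cc(CCC#N)cc1OC`: 42600 nM

In an ADME assay on TZM cells (Homo sapiens) for cytotoxicity, with a stated time of 1 days (on this read-out higher numbers stand for lower toxicity in this test and lower numbers for higher toxicity in this test), compound 2 gives the highest of the three numbers. Its nearest neighbour is compound 3, and a 3.0-fold lower number from compound 2 to compound 3 (0.48 log units; beyond the scatter) separates the two; compound 1 lies furthest away, its number well below that of compound 2. Within the data shown here, the one measured step, from compound 2 to compound 3, exchanges methylamino for methoxy on a carbonyl carbon and lowers the number by a modest but real amount.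

Compound 4 `COC(=O)c1cc(N)c(Nc2ccc(C#N)cc2)cc1Oc1c(Br)cc(CCC#N)cc1OC` differs from compound 2 in a different place: bromo in place of methoxy on an aromatic carbon. Among the measured compounds shown here, no measured step touches that ring position, so the only guidance is that the single change to compound 2 that has been measured moved the number downward. Compound 4 is therefore expected to sit somewhat lower than compound 2, with wide uncertainty: the expected step is a 2.1-fold lower number from compound 2 to compound 4 (0.33 log units; beyond the scatter). The estimate for compound 4 is 60000 nM, within a range from 15000 nM to 250000 nM.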

Compound 4, half-maximal cytotoxic concentration: 10100 nM
Compound 4: the middle estimate sits 5.9-fold (0.77 log units) above what was measured, outside the stated range (below it).
By their numbers in this assay, from the lowest: compounds 4 and 1 (each within the scatter of the next); then compound 3; then compound 2.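

In this assay, the aromatic carbon that is ortho to a large group and meta to a 2-cyanoethyl group proves to be a sensitive place in compound 2: bromo in place of methoxy there gives a 13-fold lower number from compound 2 to compound 4 (1.10 log units; beyond the scatter). Among these compounds, the only earlier step, methylamino in place of methoxy on a carbonyl carbon, gave a 3.0-fold lower number from compound 2 to compound 3 (0.48 log units; beyond the scatter), so the change on the aromatic carbon is large where the change on the carbonyl carbon was modest, and the earlier compounds gave no sign of this. The compounds shown offer nothing that explains why this single replacement, which leaves a methoxy group on the same ring, moves the number so far.

The compounds shown leave open whether the drop belongs to bromo itself or to the loss of methoxy, since no chloro, fluoro, methyl or hydroxyl group appears at this position on the core of compound 2. They also leave open whether bromo in place of methoxy would give a step of similar size with the methylamino carbonyl of compound 3, or whether replacing the second methoxy group as well would lower the number further.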